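Working notes: amide series, step from compound 3 to compound 4

A few compounds are considered here, and "the series" means these few. Any claim that something is new, unique, unknown or untested is made for them only; others in the source may bear on it.

Measured compounds:
Compound 1 `COc1cccc2sc(NC(=O)c3ccc(C(F)(F)F)cc3)nc12` reaches in a functional assay on MDA-MB-231 cells (Homo sapiens) for antiproliferative activity, read by sulforhodamine B assay (a higher number here means a weaker inhibitor of growth, a lower number a stronger inhibitor of growth), only a limit of the assay, > 10 ug/mL.
Compound 2 `Cc1cc2nc(NC(=O)Nc3ccccc3C)sc2cc1C` gives in this assay 0.1 ug/mL.
Compound 3 `COc1ccc(C(=O)Nc2nc3c(OC)cccc3s2)cc1` gives in this assay 1.25 ug/mL.

Compound 3 thus holds the higher of the two numbers; compound 2 sits well below it, and the remaining entry is a limit.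

Compound 4 `COc1cccc2sc(NC(=O)c3ccc([N+](=O)[O-])cc3)nc12` differs from compound 3 by nitro in place of methoxy on an aromatic carbon. Going by the values given here, the only measured step touching this position is an at least 8.0-fold lower number from compound 1 to compound 3 (0.90 log units; beyond the scatter), where compound 1 stood at the limit of > 10 ug/mL in this assay, at which 1 of the 3 values shown sits. Among the compounds with values here, that step shows the group here sways the number strongly, but no measured step or value covers nitro, so the direction is open. The expected step is a 3.2-fold higher number from compound 3 to compound 4 (0.51 log units; beyond the scatter). Compound 4 is therefore estimated at 4 ug/mL, within a range of 1.2 ug/mL to 12 ug/mL.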

Compound 4, concentration for 50% growth inhibition: > 10 ug/mL
Compound 4: no number, only a limit; the forecaster's own chance of this, stated with the estimate: 35%; middle value at least 2.5-fold (0.39 log units) away from the limit.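

Nitro in place of methoxy gives an at least 8.0-fold higher number from compound 3 to compound 4 (0.90 log units; beyond the scatter), so nitro joins trifluoromethyl as a second group that falls well short of methoxy at this position. Compound 1 and compound 4 both stop at a limit, so the step between them cannot be read and the two groups cannot be ranked: the limit of > 10 ug/mL in this assay, at which 2 of the 4 values shown sit.

Among these amides only methoxy gives a number at this position, so no trend across groups can be drawn. On these data alone, whether an amine or a hydroxyl here would match or better compound 3 at 1.25 ug/mL stays open.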